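The compounds below may be only part of what the source reports. "The series", "measured", "known", "first", "only" and "open" are said of these compounds alone.

Within the data shown here, in a physicochemical assay for permeability, using PAMPA (a higher number here means that the compound crosses the layer faster, a lower number that the compound crosses the layer more slowly), compound 2 `Cc1cccc(F)c1-c1nc(CN2CCC(C(=O)NCCCN3C[C@H](C)C[C@H](C)C3)CC2)c(C)o1` gives 234 10^-6 cm/s, the only true number so far. Compound 1 `Cc1oc(-c2ccc(Cl)cc2)nc1CN1CCC(C(=O)NCCCN2C[C@H](C)C[C@H](C)C2)CC1` reads > 635 10^-6 cm/s, which is a limit of the assay and not a number. Compound 3 `Cc1cccc(-c2nc(CN3CCC(C(=O)NCCCN4C[C@H](C)C[C@H](C)C4)CC3)c(C)o2)c1` has not yet been measured and differs from compound 2 in one place: 3-methylphenyl in place of 2-fluoro-6-methylphenyl on an aromatic carbon. In short, 3-methylphenyl stands in place of 2-fluoro-6-methylphenyl on an aromatic carbon.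

Among the measured compounds shown here, only one measured step bears on this change. Putting 2-fluoro-6-methylphenyl in place of 4-chlorophenyl gave an at least 2.7-fold lower number from compound 1 to compound 2 (0.43 log units; beyond the scatter), a step beyond the scatter. From the compounds shown here alone, compound 3 gives up that same 2-fluoro-6-methylphenyl group, so part of the step of an at least 2.7-fold lower number from compound 1 to compound 2 (0.43 log units; beyond the scatter) may be recovered, although a single step is thin evidence and its full size is unknown. The estimated step, towards a higher number, is a 1.8-fold higher number from compound 2 to compound 3 (0.25 log units; within the scatter). For compound 3 the estimate is 420 10^-6 cm/s, with an expected range of 190 10^-6 cm/s to 900 10^-6 cm/s.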

Compound 3, apparent permeability: 279 10^-6 cm/s
Compound 3: middle estimate off by 1.5-fold (0.18 log units), on the high side; low and high end bracket the measured number.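

Swapping 2-fluoro-6-methylphenyl for 3-methylphenyl in this assay gives a 1.2-fold higher number from compound 2 to compound 3 (0.08 log units; within the scatter), so these two groups cannot be told apart at this position. The lower reading seen earlier is therefore not tied to 2-fluoro-6-methylphenyl alone, since 3-methylphenyl in place of 4-chlorophenyl also gives an at least 2.2-fold lower number from compound 1 to compound 3 (0.35 log units; beyond the scatter). Compound 1 reads > 635 10^-6 cm/s, which is a limit and not a number, so the full size of that step stays unknown: the limit of > 635 10^-6 cm/s in this assay, at which 1 of the 3 values shown sits.

The compounds shown leave open whether the higher reading of compound 1 goes with the chlorine itself or with where a group sits on the phenyl ring. A 4-methylphenyl, a 3-chlorophenyl or an unsubstituted phenyl group at this position would separate these two possibilities.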